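This account rests on a few compounds, and the source may have more. Where it says the series, first, only, none or still open, it means among the compounds named here.

Compound 1 `CN1CCN(c2nc(-c3ccc(Cl)c(Cl)c3)nc3[nH]cnc23)CC1` and compound 3 `CN1CCN(c2nc(-c3ccc(Cl)cc3)nc3[nH]cnc23)CC1` share one core, while compound 2 `Clc1ccc(Cl)c(-c2nc(N3CCCCC3)c3nc[nH]c3n2)c1` and the still unmeasured compound 4 `Clc1cccc(-c2nc(N3CCCCC3)c3nc[nH]c3n2)c1` share another; the difference between the two cores is not broken down here. In an assay on cells for displacement of a labelled ligand from adenosine receptor A3 (Homo sapiens), read by scintillation counting and radioligand binding, with a stated time of 180 min (on this read-out higher numbers stand for weaker inhibition and lower numbers for stronger inhibition), compound 1 gives 39.8 nM, and compound 3 gives 39.8 nM. The change from compound 1 to compound 3 is hydrogen in place of chloro on an aromatic carbon, and the step of no change at the digits printed from compound 1 to compound 3 (within the scatter) was seen. Compound 2 gives 200 nM. The change from compound 2 to compound 4 is hydrogen in place of chloro on an aromatic carbon, the same kind of change, though the leaving chloro here sits ortho to a large group and para to a chloro group rather than ortho to a chloro group and meta to a large group. A step of about a 1.3-fold lower number from compound 2 to compound 4 (0.10 log units; within the scatter) is expected from compound 2 to compound 4, resting on the unchanged step no change at the digits printed from compound 1 to compound 3 (within the scatter). Compound 4 is therefore estimated at 160 nM, between 50 nM and 500 nM.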

Compound 4, inhibition constant: 39.8 nM
Compound 4: the middle estimate sits 4.0-fold (0.60 log units) above what was measured; measured number outside the range, below it.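

In this assay, replacing chloro with hydrogen gives a 5.0-fold lower number from compound 2 to compound 4 (0.70 log units; beyond the scatter), so the result of this change on one core does not carry over unchanged to the other: the same change on two cores in this assay, no change at the digits printed (within the scatter) from compound 1 to compound 3 and a 5.0-fold lower number (0.70 log units; beyond the scatter) from compound 2 to compound 4, 5.0-fold (0.70 log units) apart, beyond the scatter of two such steps What this does not show is the reason for the difference, as the two pairs differ in their cores and the chloro that leaves also sits at a different place on the ring, so the two influences cannot be told apart. Going by these compounds alone, with only one pair on each core, it also cannot show how general either step is.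

The compounds shown leave open how a fluoro, methyl or methoxy group would read in place of the chloro that is ortho to a large group. They also leave open how the change would read with the leaving chloro at the same place on both cores.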